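Trading a Two-Ring Group for 2-Methoxypyrimidin-5-yl

The source may report more compounds than this note shows. Statements on the series, on what has been measured and on what is new or still open speak of the compounds shown alone.

Among the measured compounds shown here, in a physicochemical assay for lipophilicity (on this read-out higher numbers stand for higher lipophilicity and lower numbers for lower lipophilicity), compound 3 `O=C(O)C[C@H](CCCCCCc1ccc2c(n1)NCCC2)c1ccc2c(c1)OCC2` gives 2.39, level with compound 2 `O=C(O)C[C@H](CCCCCCc1ccc2c(n1)NCCC2)c1cnc2ccccc2c1` at 2.39, and these two share the highest number so far. Compound 1 `O=C(O)C[C@H](CCCCCCc1ccc2c(n1)NCCC2)c1cncnc1` gives 0.1. Compound 4 `COc1ncc([C@@H](CCCCCCc2ccc3c(n2)NCCC3)CC(=O)O)cn1` is built from compound 3 by one change: a group of 8 heavy atoms (5 carbon, 2 nitrogen, 1 oxygen; one six-membered aromatic ring with 2 hetero atoms) in place of a group of 9 heavy atoms (8 carbon, 1 oxygen; one five-membered non-aromatic ring with 1 hetero atom, one six-membered aromatic ring of carbon only), on a saturated chain carbon bound to two saturated chain carbons. Two measured steps are large: a number 2.29 log units higher from compound 1 to compound 2 (beyond the scatter) and a number 2.29 log units higher from compound 1 to compound 3 (beyond the scatter). A third shows no change at the digits printed from compound 2 to compound 3 (within the scatter). The entering group keeps the six-membered aromatic ring with 2 hetero atoms found in the pyrimidin-5-yl of compound 1, so the large step of a number 2.29 log units higher from compound 1 to compound 3 (beyond the scatter) should largely run in reverse. The expected move in this assay is a large fall, a number 1.79 log units lower from compound 3 to compound 4 (beyond the scatter). Compound 4 is estimated at 0.6, with an expected range of 0.1 to 1.1.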

Compound 4, partition coefficient: 0.65
Beside the measured number, compound 4's estimate is 0.05 log units below it; measured number inside the range.
By their numbers in this assay, from the lowest: compound 1; then compound 4; then compounds 2 and 3 (each within the scatter of the next).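

In this assay, 2-methoxypyrimidin-5-yl at this saturated chain carbon gives a number 1.74 log units lower from compound 3 to compound 4 (beyond the scatter) and a number 1.74 log units lower from compound 2 to compound 4 (beyond the scatter), so the two different two-ring groups lose the same ground to it. Methoxy in place of hydrogen on an aromatic carbon gives a number 0.55 log units higher from compound 1 to compound 4 (beyond the scatter) and closes only a modest part of the gap between compound 1 and the two-ring compounds. No measured evidence accounts for these steps. Still open, as far as these compounds go, is whether ethoxy or a dimethylamino group in place of methoxy on the same ring would move the number further, and by how much.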